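A few compounds are considered here, and "the series" means these few. Any claim that something is new, unique, unknown or untested is made for them only; others in the source may bear on it.

Measured so far: compound 1 `COC(=O)CC1c2ccccc2N=C(N2CCOCC2)N1c1ccccc1` gives 14% in a functional assay on cells (Oocyte) for inhibition of Voltage-dependent T-type calcium channel subunit alpha-1H (Homo sapiens), tested at 100 uM; a lower number here means less inhibition, a higher number more inhibition at the concentration tested (going by the name of the read-out); compound 2 `COC(=O)CC1c2ccccc2N=C(N2CCN(C)CC2)N1c1ccccc1` gives 15% in this assay.

Within the data shown here, on these two numbers compound 2 holds the higher value, but the only measured step, a number 1 percentage points higher from compound 1 to compound 2 (within the scatter), lies within the scatter, so the two compounds cannot be told apart. Compound 3 `COC(=O)CC1c2ccccc2N=C(c2ccccc2)N1c1ccccc1` carries the change (phenyl in place of 4-methylpiperazin-1-yl on a carbon with a double bond to nitrogen). Among the measured compounds shown here, no measured step covers an exchange of this kind: the one known step, a number 1 percentage points higher from compound 1 to compound 2 (within the scatter), concerns a different pair of groups and is itself within the scatter, so it gives neither a direction nor a size to lean on. Compound 3 is therefore expected to show a step of a number 5 percentage points higher from compound 2 to compound 3 (within the scatter) from compound 2, with no direction beyond the scatter claimed and a wide margin for surprise. The estimate for compound 3 in this assay is 20%, with a range from 2% to 45%.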

Compound 3, a percentage reported as inhibition, at one concentration (the size of the read-out at that concentration, not a potency): 51.5%
Estimate against measurement, compound 3: 31.5 percentage points below, outside the stated range (above it).
By their numbers in this assay, from the lowest: compounds 1 and 2 (each within the scatter of the next); then compound 3.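

In this assay, the place on the carbon with a double bond to nitrogen, between two ring nitrogen atoms, proves sensitive to the group it carries: phenyl in place of 4-methylpiperazin-1-yl gives a large rise (a number 36.5 percentage points higher from compound 2 to compound 3 (beyond the scatter)), and phenyl in place of morpholin-4-yl gives another (a number 37.5 percentage points higher from compound 1 to compound 3 (beyond the scatter)). The two non-aromatic rings could not be told apart, so only the aromatic carbon ring shows that a change here can move the read-out beyond the scatter. Nothing available accounts for this rise.

As far as these compounds go, it stays open whether the increase follows from the aromatic ring or from the absence of ring nitrogen, which a cyclohexyl or pyridyl group here would help separate. Also open, from the compounds shown here alone, is how an open-chain amine such as dimethylamino would compare here, or how a carboxylic acid would compare in place of the methyl ester.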